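Chalcone hemolysis inhibition: swapping hydroxyls for a bromine

A few compounds are considered here, and "the series" means these few. Any claim that something is new, unique, unknown or untested is made for them only; others in the source may bear on it.

Measured compounds:
Compound 1 `COc1cc(OC)c(OC)cc1/C=C/C(=O)c1ccc(O)cc1`: 2.29 ug/mL
Compound 2 `COc1cc(OC)c(OC)cc1/C=C/C(=O)c1cc(O)ccc1O`: 2.1 ug/mL

Of the compounds shown here, two have been tested in a functional assay on cells (Erythrocyte, Rattus norvegicus) for inhibition, read by hemolysis, with a stated time of 1 h; a lower number here means a stronger inhibitor, a higher number a weaker inhibitor. Compound 1 gives 2.29 ug/mL, and compound 2 gives 2.1 ug/mL. Going by the values given here, the one step between them, a 1.1-fold lower number from compound 1 to compound 2 (0.04 log units; within the scatter), shows that the change in hydroxyl pattern on the ring attached to the carbonyl carbon left the number unchanged. Among the compounds with values here, compound 2 therefore stands as one of two values that cannot be told apart; compound 1 is its only neighbour.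

Compound 3 `COc1cc(OC)c(OC)cc1/C=C/C(=O)c1ccc(Br)cc1` has not yet been measured in this assay. It differs from compound 2 in one place: 4-bromophenyl in place of 2,5-dihydroxyphenyl on a carbonyl carbon. Within the data shown here, no measured step bears directly on this exchange; the single step known concerns hydroxyl placement only, and it was within the scatter. Going by these compounds, the replacement of both hydroxyls by a 4-bromophenyl group is untested here, so the expectation for compound 3 rests on the observation that the ring on the carbonyl carbon has so far tolerated change. Compound 3 is expected to give about 2.5 ug/mL, with a range from 1 ug/mL to 6.5 ug/mL, and the step of a 1.2-fold higher number from compound 2 to compound 3 (0.08 log units; within the scatter) is estimated to lie within or near the scatter.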

Compound 3, half-maximal inhibitory concentration: 2.3 ug/mL
For compound 3 the middle estimate is 1.1-fold (0.04 log units) above the measured one; measured number inside the range.
By their numbers in this assay, from the lowest: compounds 2, 1 and 3 (each within the scatter of the next).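

In this assay, the ring on the carbonyl carbon need not carry any hydrogen-bond donors or acceptors: with 4-bromophenyl in place of 2,5-dihydroxyphenyl, a 1.1-fold higher number from compound 2 to compound 3 (0.04 log units; within the scatter), the two numbers cannot be told apart. The single exchange of bromo for hydroxy on an aromatic carbon reads the same way, a 1.0-fold higher number from compound 1 to compound 3 (0.00 log units; within the scatter), so among these compounds neither hydroxyl pattern is required for a value of this size. Nothing at hand explains why these numbers stay together.

What the compounds shown leave open is whether any group on this ring can shift the number beyond the scatter. An amine or a carboxylic acid on this ring would be a sharper test of that than the bromo and hydroxy groups seen so far.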